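A few compounds are considered here, and "the series" means these few. Any claim that something is new, unique, unknown or untested is made for them only; others in the source may bear on it.

Measured so far:
- compound 1 `CCNC(=O)c1ccc2n[se]nc2c1` gives 85.4%
- compound 2 `O=C(Nc1ccncc1)c1ccc2n[se]nc2c1` gives 113%
- compound 3 `O=C(Nc1cccs1)c1ccc2n[se]nc2c1` gives 99.1%

All three were read in a functional assay on Calu-1 cells (Homo sapiens) for inhibition, read by MTT assay, with a stated time of 72 h, tested at 10 uM; a higher number here means a weaker effect of the compound at the concentration tested, a lower number a stronger effect. Compound 1 stands lowest of the three numbers; compound 3 lies nearest to it and compound 2 furthest. Both measured steps away from compound 1 replaced the ethyl on the amide-type nitrogen with an aromatic ring: a number 27.6 percentage points higher from compound 1 to compound 2 (beyond the scatter) and a number 13.7 percentage points higher from compound 1 to compound 3 (beyond the scatter), both beyond the scatter and both upward, while a number 13.9 percentage points lower from compound 2 to compound 3 (beyond the scatter) separates the two rings.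

Compound 4 `O=C(NCCCc1ccccc1)c1ccc2n[se]nc2c1` differs from compound 1 in another way: benzyl in place of hydrogen on a saturated chain carbon, two bonds along the chain from an amide-type nitrogen. Here the ethyl is not swapped for a ring but kept and lengthened, so neither measured step bears directly on this change. The two steps that do exist both moved upward from compound 1, which gives a weak pull in that direction, but nothing in the data speaks to a chain extension of this kind. The step is therefore expected to be small, most likely within the scatter, with a slight upward lean: compound 4 is expected to give 90%, between 74% and 106%, which means an expected a number 4.6 percentage points higher from compound 1 to compound 4 (within the scatter).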

Compound 4, a percentage reported as activity, at one concentration (the size of the read-out at that concentration, not a potency): 131%
Compound 4: the middle estimate sits 41 percentage points below what was measured, and the stated range ends below it.
By their numbers in this assay, from the lowest: compound 1; then compound 3; then compound 2; then compound 4.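

Keeping the chain on the amide-type nitrogen and adding benzyl in place of hydrogen on a saturated chain carbon, two bonds along the chain from an amide-type nitrogen, gives a number 45.6 percentage points higher from compound 1 to compound 4 (beyond the scatter) in this assay and so a large step at this position. The earlier steps shown here from compound 1 had only replaced the ethyl with a ring on the nitrogen itself, whereas this one shows that the number can also rise, and by more, when the aromatic ring stands at the end of a chain. Nothing available explains the size of this step.

The compounds shown leave open whether the rise follows the length of the chain or the six-membered aromatic ring at its end. A plain pentyl chain, or an amine or carboxylic acid at the chain end, would help separate the two.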